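Aromatic ring in place of butyl on compound 1's side chain

The source may hold more compounds than are shown below. What is called first, only, known or untested is meant among the compounds shown, and "the series" means these compounds.

Compound 1 `CCCCCNc1ncnc2c1ncn2[C@@H]1O[C@H](CO)[C@@H](O)[C@H]1O` gives the highest number among the three compounds measured in an assay on isolated protein for binding affinity to Equilibrative nucleoside transporter 1 (Homo sapiens) (on this read-out lower numbers stand for stronger inhibition and higher numbers for weaker inhibition), namely 13500 nM. Compound 2 `OC[C@H]1O[C@@H](n2cnc3c(SCC4CCCCC4)ncnc32)[C@H](O)[C@@H]1O` gives 1550 nM and compound 3 `OC[C@H]1O[C@@H](n2cnc3c(CSc4ccc(Br)cc4)ncnc32)[C@H](O)[C@@H]1O` gives 178 nM. The step of an 8.7-fold lower number from compound 1 to compound 2 (0.94 log units; beyond the scatter) and the step of a 76-fold lower number from compound 1 to compound 3 (1.88 log units; beyond the scatter) show that exchanging the pentylamino group lowers the number, most so when an aromatic ring enters. Compound 4 `Cc1c(CNc2ncnc3c2ncn3[C@@H]2O[C@H](CO)[C@@H](O)[C@H]2O)cccc1[N+](=O)[O-]` keeps the nitrogen link but changes the chain: 2-methyl-3-nitrophenyl in place of butyl on a saturated chain carbon bound to a nitrogen on an aromatic ring. Those two steps bear only loosely on this change, since both replaced the nitrogen link as well. An aromatic ring entering, as in compound 3, suggests a lower number; a modest step of a 5.4-fold lower number from compound 1 to compound 4 (0.73 log units; beyond the scatter) is expected. The estimate for compound 4 in this assay is 2500 nM, within 500 nM to 10000 nM.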

Compound 4, half-maximal inhibitory concentration: 427 nM
The estimate for compound 4 lay 5.9-fold (0.77 log units) above the measured number; measured number below the stated range.
By their numbers in this assay, from the lowest: compound 3; then compound 4; then compound 2; then compound 1.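

With the nitrogen link kept, 2-methyl-3-nitrophenyl in place of butyl gives a 32-fold lower number from compound 1 to compound 4 (1.50 log units; beyond the scatter) in this assay, so a large step needs no change of that link. The earlier steps shown here from compound 1 replaced the link and the chain together and could not show this. No measurement here explains why the number falls.

From the compounds shown here alone, it remains open whether the aromatic ring alone carries the step or its methyl and nitro groups share in it. An unsubstituted phenyl, or a carboxylic acid in place of the nitro group, would help separate these.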